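Methyl on the Four-Membered Ring and Clearance

The source may report more compounds than this note shows. Statements on the series, on what has been measured and on what is new or still open speak of the compounds shown alone.

Measured in an ADME assay on liver for metabolic stability, with Liver microsome (Homo sapiens) as the target, read by LC-MS, using microsomes, with a stated time of 5 h; a higher number here means faster removal of the compound, a lower number slower removal:
compound 1 `C[C@]1(O)C[C@](c2cccc(OC(F)(F)F)c2)([C@H](O)c2ccccn2)C1` gives 117 mL/min/kg
compound 2 `O[C@H](c1ccccn1)[C@]1(c2cccc(OC(F)(F)F)c2)C[C@H](O)C1` gives 150 mL/min/kg
compound 3 `O[C@H](c1ccccn1)[C@]1(c2ccc(C(F)(F)F)cc2)C[C@@H](O)C1` gives 33.3 mL/min/kg

Compound 4 `C[C@]1(O)C[C@@](c2ccc(C(F)(F)F)cc2)([C@H](O)c2ccccn2)C1` has not yet been measured. The difference between the cores of compound 2 and compound 3 is not broken down here; compound 3 stands lowest of the three in this assay, beyond the scatter from both others. One change is seen twice. From compound 2 to compound 1 it is methyl in place of hydrogen on a saturated ring carbon, and it gave a 1.3-fold lower number from compound 2 to compound 1 (0.11 log units; within the scatter). From compound 3 to compound 4 the same change is made: methyl in place of hydrogen on a saturated ring carbon. For compound 4 the expected step is a 1.2-fold lower number from compound 3 to compound 4 (0.08 log units; within the scatter), which rests on a 1.3-fold lower number from compound 2 to compound 1 (0.11 log units; within the scatter). Compound 4 is therefore estimated at 28 mL/min/kg in this assay, between 13 mL/min/kg and 60 mL/min/kg.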

Compound 4, clearance: 50 mL/min/kg
Estimate against measurement, compound 4: 1.8-fold (0.25 log units) below, within the range that was stated.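

In this assay, placing the methyl on the four-membered ring gave a 1.5-fold higher number from compound 3 to compound 4 (0.18 log units; within the scatter), a step that stays inside what repeated measurements normally show. The two cores do not differ measurably in how they respond to this change: the same change on two cores in this assay, a 1.3-fold lower number (0.11 log units; within the scatter) from compound 2 to compound 1 and a 1.5-fold higher number (0.18 log units; within the scatter) from compound 3 to compound 4, 1.9-fold (0.28 log units) apart, within the scatter of two such steps. On these two cores, then, the methyl produced no step beyond the scatter, but two pairs cannot establish a rule for the whole series, and a small real difference could lie hidden within the scatter.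

The compounds shown leave open whether a different group on the same saturated ring carbon, such as an ethyl, a longer chain or an amine, would give a step beyond the scatter.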